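Ring substituent on the amide-type nitrogen: compound 1 to compound 3

The source may report more compounds than this note shows. Statements on the series, on what has been measured and on what is new or still open speak of the compounds shown alone.

Measured so far:
compound 1 `O=C(NCCCCc1ccccc1)c1cccc(C2SCC(=O)N2c2cnccn2)c1` — > 1000 nM, a limit only
compound 2 `O=C(NCCCCn1cccn1)c1cccc(C2SCC(=O)N2c2cccnc2)c1` — > 1000 nM, a limit only

Two compounds have been run in a functional assay on HOS-TE85 cells (Homo sapiens) for inhibition, read by CCK-8 assay, with a stated time of 72 h (a higher number here means a weaker inhibitor, a lower number a stronger inhibitor), and neither gives a number. For compound 1 the result is a limit, > 1000 nM. For compound 2 the result is also a limit, > 1000 nM. Both results are the limit of > 1000 nM in this assay, at which 2 of the 2 values shown sit, so compound 1 stands at the same limit as the one other compound shown, and no step between measured compounds can be drawn; nothing here tells which way any change would move the read-out.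

Compound 3 `O=C(NCCCCc1ccccc1)c1cccc(C2SCC(=O)N2c2ccc(-c3ccccc3)cc2)c1` is not yet measured. It differs from compound 1 in one place: 4-phenylphenyl in place of pyrazin-2-yl on an amide-type nitrogen in a ring. The two measured results offer no basis for expecting a gain or a loss, so the expected step that the limit leaves unreadable from compound 1 to compound 3 is none beyond the scatter. For compound 3 the expected value in this assay is 3000 nM, within a range from 500 nM to 20000 nM, and a result that is again only a limit is the more probable outcome.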

Compound 3, half-maximal inhibitory concentration: > 1000 nM
Compound 3: no number, only a limit (the forecaster's own chance of this, stated with the estimate: 60%); the middle value does not contradict the limit.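

No step can be read from compound 1 to compound 3 in this assay, because both results are limits and not numbers: the limit of > 1000 nM in this assay, at which 3 of the 3 values shown sit.

The compounds shown leave open whether any group on the amide-type nitrogen in the ring gives a readable value in this assay, and how far such a value would lie from these limits.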